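Swapping the group on the aromatic nitrogen of compound 3

The source may hold more compounds than are shown below. What is called first, only, known or untested is meant among the compounds shown, and "the series" means these compounds.

Compound 1, `CC(C)=CCn1ccc2cc(/C(C)=C/C(=O)Nc3ccccc3OCCCC(=O)O)ccc21`, gives 120 nM in an assay on Prostate gland for inhibition of steroid 5-alpha-reductase (Rattus norvegicus); a higher number here means a weaker inhibitor, a lower number a stronger inhibitor.
Compound 2, `C/C(=C\C(=O)Nc1ccccc1OCCCC(=O)O)c1ccc2c(ccn2Cc2ccc(F)cc2)c1`, gives 97 nM.
Compound 3, `COc1ccc(Cn2ccc3cc(/C(C)=C/C(=O)Nc4ccccc4OCCCC(=O)O)ccc32)cc1`, gives 480 nM.

Compound 3 carries the highest number of the three: a 4.0-fold higher number from compound 1 to compound 3 (0.60 log units; beyond the scatter) and a 4.9-fold higher number from compound 2 to compound 3 (0.69 log units; beyond the scatter). Compound 4, `C/C(=C\C(=O)Nc1ccccc1OCCCC(=O)O)c1ccc2c(ccn2C(CC(C)C)c2ccccc2)c1`, has not yet been measured; the change is 3-methyl-1-phenylbutyl in place of 4-methoxybenzyl on an aromatic nitrogen. The step that bears on it is a 4.9-fold higher number from compound 2 to compound 3 (0.69 log units; beyond the scatter), a modest rise when methoxy replaced fluoro, and compound 1, without any methoxy, stands at 120 nM. Within the data shown here, no measured step covers the 3-methyl-1-phenylbutyl branch, so that part remains unknown. A modest downward step is therefore expected, a 4.4-fold lower number from compound 3 to compound 4 (0.64 log units; beyond the scatter). Compound 4 is estimated at 110 nM, with a range from 35 nM to 350 nM.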

Compound 4, half-maximal inhibitory concentration: 6.3 nM
For compound 4 the middle estimate is 17-fold (1.24 log units) above the measured one; measured number outside the range, below it.
By their numbers in this assay, from the lowest: compound 4; then compounds 2 and 1 (each within the scatter of the next); then compound 3.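

Measured against each earlier group on the aromatic nitrogen, 3-methyl-1-phenylbutyl gives a large fall: against 4-methoxybenzyl (a 76-fold lower number from compound 3 to compound 4 (1.88 log units; beyond the scatter)), against 4-fluorobenzyl (a 15-fold lower number from compound 2 to compound 4 (1.19 log units; beyond the scatter)) and against 3-methylbut-2-en-1-yl (a 19-fold lower number from compound 1 to compound 4 (1.28 log units; beyond the scatter)). The earlier compounds shown here showed only modest steps at this position, so it can support much larger changes than they revealed. No evidence here accounts for the gain.

The compounds shown do not separate the phenyl ring from the rest of the new group. A 1-phenylethyl group on the same nitrogen would help show which part carries the gain.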